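Methoxy in Place of Hydrogen on Compound 3

The compounds below may be only part of what the source reports. "The series", "measured", "known", "first", "only" and "open" are said of these compounds alone.

Three glycoconjugates have been measured in a functional assay on MCF7 cells (Homo sapiens) for cytotoxicity, read by sulforhodamine B assay, with a stated time of 48 h; on this read-out higher numbers stand for weaker inhibition and lower numbers for stronger inhibition. Compound 1 `COc1ccc2c(c1)c(C=O)cn2Cc1cn([C@@H]2O[C@H](COC(C)=O)[C@@H](OC(C)=O)[C@H](OC(C)=O)[C@H]2OC(C)=O)nn1` gives only a limit in this assay, > 200000 nM. Compound 2 `COc1ccc2c(c1)c(/C=N/O)cn2Cc1cn([C@@H]2O[C@H](COC(C)=O)[C@@H](OC(C)=O)[C@H](OC(C)=O)[C@H]2OC(C)=O)nn1` carries an oxime where compound 1 carries an aldehyde. In this assay, among the measured compounds shown here, compound 2 gives 51000 nM, and the step of an at least 3.9-fold lower number from compound 1 to compound 2 (0.59 log units; beyond the scatter) is the only single change with a measured outcome. Compound 3 `CC(=O)OC[C@H]1O[C@@H](n2cc(Cn3cc(/C=C4/C(=O)Nc5ccc(F)cc54)c4ccccc43)nn2)[C@H](OC(C)=O)[C@@H](OC(C)=O)[C@@H]1OC(C)=O` gives 40400 nM; this is the lowest of the two numbers, yet it sits within the scatter of compound 2, so the two cannot be ranked.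

Compound 4 `COc1ccc2c(c1)c(/C=C1/C(=O)Nc3ccc(F)cc31)cn2Cc1cn([C@@H]2O[C@H](COC(C)=O)[C@@H](OC(C)=O)[C@H](OC(C)=O)[C@H]2OC(C)=O)nn1` differs from compound 3 in one place: methoxy in place of hydrogen on an aromatic carbon. For the measured compounds named here, no measured step tests this change. Going by the values given here, the one step with a number, from compound 1 to compound 2, alters the substituent on the other ring system and leaves the methoxy untouched, so it offers no guide to what the methoxy itself contributes. With nothing pointing either way, the author expects the step of a 1.2-fold lower number from compound 3 to compound 4 (0.06 log units; within the scatter) to stay within the scatter, with no direction favoured. Compound 4 is therefore estimated at 35000 nM in this assay, with a range from 12000 nM to 110000 nM.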

Compound 4, half-maximal inhibitory concentration: > 200000 nM
Compound 4 was reported as a limit (the forecaster's own chance of this, stated with the estimate: 8%); middle value at least 5.7-fold (0.75 log units) from the limit.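

In this assay the methoxy on this aromatic carbon is not a neutral change: it gives an at least 4.9-fold higher number from compound 3 to compound 4 (0.69 log units; beyond the scatter), so with this group of 12 heavy atoms on the other side of the molecule, hydrogen gives the lower number of the two. With the methoxy held in place, replacing the oxime with that same group gives an at least 3.9-fold higher number from compound 2 to compound 4 (0.59 log units; beyond the scatter), so the group that accompanies a measurable number in compound 3 does not do so in compound 4. The step from compound 1 to compound 4 cannot be read because both compounds end at a limit: the limit of > 200000 nM in this assay, at which 2 of the 4 values shown sit.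

The compounds shown leave open whether this rise is particular to methoxy, or whether a hydroxyl, a chlorine or the longer ethoxy on the same aromatic carbon would give the same outcome. Also open, on these data alone, is whether hydrogen in place of methoxy would shift the numbers when the shared core carries the oxime of compound 2 or the aldehyde of compound 1, as it does with the group in compound 3.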